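Halogen in place of methoxy at the benzylthio para position

The compounds below may be only part of what the source reports. "The series", "measured", "known", "first", "only" and "open" are said of these compounds alone.

Compound 3 `COc1ccc(CSc2nnc([C@@H](C)c3ccc4cc(OC)ccc4c3)n2-c2ccc(F)cc2)cc1` gives 22800 nM in a functional assay on LNCaP cells (Homo sapiens) for cytotoxicity, read by MTT assay; a higher number here means a weaker inhibitor, a lower number a stronger inhibitor. Among the three measured compounds it stands second highest: compound 2 `COc1cccc(CSc2nnc([C@@H](C)c3ccc4cc(OC)ccc4c3)n2-c2ccc(F)cc2)c1` gives 14500 nM, the gap being a 1.6-fold higher number from compound 2 to compound 3 (0.20 log units; within the scatter), while compound 1 `COc1ccc2cc([C@H](C)c3nnc(SCc4ccc(F)cc4)n3-c3ccc(F)cc3)ccc2c1` gives 104000 nM, a gap of a 4.6-fold lower number from compound 1 to compound 3 (0.66 log units; beyond the scatter). Compound 4 `COc1ccc2cc([C@H](C)c3nnc(SCc4ccc(Cl)cc4)n3-c3ccc(F)cc3)ccc2c1` differs from compound 3 in one place: chloro in place of methoxy on an aromatic carbon.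

Going by the values given here, the step that bears on this is the one from compound 1 to compound 3, where methoxy replaced fluoro on the same aromatic carbon and the number fell, a 4.6-fold lower number from compound 1 to compound 3 (0.66 log units; beyond the scatter). The step from compound 1 to compound 2, a 7.2-fold lower number from compound 1 to compound 2 (0.86 log units; beyond the scatter), moves the same group to another position and is less directly comparable. Going back from methoxy to a halogen is therefore expected to raise the number, though chloro is not fluoro and the return need not be complete; the expected step is a 2.0-fold higher number from compound 3 to compound 4 (0.30 log units; within the scatter), modest and beyond the scatter.

Compound 4 is estimated at 45000 nM, with a range of 18000 nM to 110000 nM.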

Compound 4, half-maximal inhibitory concentration: > 400000 nM
Compound 4 gave a limit, no number; the forecaster's own chance of this, stated with the estimate: 10%; at least 8.8-fold (0.94 log units) between middle value and limit.
By their numbers in this assay, from the lowest: compounds 2 and 3 (each within the scatter of the next); then compound 1. At a limit, above all of these: compound 4.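

Notes on the 4-substituent of the benzyl group. In this assay compound 4 reads as a limit and not a number: the limit of > 400000 nM in this assay, at which 1 of the 4 values shown sits.

This position does not respond evenly to halogens. Chloro in place of methoxy gives an at least 17-fold higher number from compound 3 to compound 4 (1.24 log units; beyond the scatter) and 4-chlorophenyl in place of 3-methoxyphenyl gives an at least 27-fold higher number from compound 2 to compound 4 (1.44 log units; beyond the scatter), both steps larger than any among the earlier compounds. Chloro in place of fluoro on the same aromatic carbon still gives an at least 3.8-fold higher number from compound 1 to compound 4 (0.58 log units; beyond the scatter), so the two halogens are not interchangeable here and the loss of methoxy alone does not account for the result.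

Open, on these data alone, is whether the lower numbers belong to methoxy itself or extend to other groups on this carbon, such as hydroxy, ethoxy or an amine. Also open, as far as these compounds go, is how chloro behaves in the position held by the 3-methoxyphenyl group of compound 2.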